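The source may hold more compounds than are shown below. What is called first, only, known or untested is meant among the compounds shown, and "the series" means these compounds.

Measured compounds in this set:
Compound 1, `C=C1C(=O)[C@]23C[C@@]1(O)CC[C@H]2c1ccc(O)c(C)c1[C@@H]3Cn1cc(-c2ccccn2)nn1` — 2240 nM
Compound 2, `C=C1C(=O)[C@]23C[C@@]1(O)CC[C@H]2c1ccc(O)c(C)c1[C@@H]3Cn1cc(-c2ccc(C)cc2)nn1` — 370 nM

In a functional assay on MCF7 cells (Homo sapiens) for cytotoxicity, read by MTT assay, with a stated time of 4 days (on this read-out lower numbers stand for stronger inhibition and higher numbers for weaker inhibition), compound 2 gives 370 nM, the lowest of the two numbers recorded so far. Its nearest neighbour is compound 1, which gives 2240 nM in this assay, and the two are separated by the step of a 6.1-fold lower number from compound 1 to compound 2 (0.78 log units; beyond the scatter), a change that swapped the whole aryl group on the triazole. Compound 3, `C=C1C(=O)[C@]23C[C@@]1(O)CC[C@H]2c1ccc(O)c(C)c1[C@@H]3Cn1cc(-c2ccc(Br)cc2)nn1`, differs from compound 2 in one place only: bromo in place of methyl on an aromatic carbon, the bromo entering para to a large group on a six-membered aromatic ring of carbon only. Among the measured compounds shown here, no measured step bears directly on this exchange; the only step available concerns a different group, pyridin-2-yl against 4-methylphenyl, and says nothing about trading a methyl for a bromo on that ring. With no guidance in either direction, compound 3 is expected to stay close to compound 2 in this assay, with the step of a 1.1-fold higher number from compound 2 to compound 3 (0.03 log units; within the scatter) anticipated to lie within the scatter. Compound 3 is therefore estimated at 400 nM, within the range 150 nM to 1100 nM.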

Compound 3, half-maximal inhibitory concentration: 270 nM
Beside the measured number, compound 3's estimate is 1.5-fold (0.17 log units) above it, and the stated range covers the measured number.
By their numbers in this assay, from the lowest: compounds 3 and 2 (each within the scatter of the next); then compound 1.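

In this assay, among the compounds shown here, this is the first exchange made on the phenyl ring itself, at the aromatic carbon para to a large group, and a 1.4-fold lower number from compound 2 to compound 3 (0.14 log units; within the scatter) shows that methyl and bromo cannot be told apart at this position. The advantage over the pyridin-2-yl compound therefore holds for 4-bromophenyl as well as for 4-methylphenyl, with an 8.3-fold lower number from compound 1 to compound 3 (0.92 log units; beyond the scatter) standing beside the earlier 6.1-fold lower number from compound 1 to compound 2 (0.78 log units; beyond the scatter) and both steps lying beyond the scatter. No evidence is available to account for any of these steps.

The compounds shown leave open whether the position tolerates substituents more broadly, as only methyl and bromo stand there, and whether a methoxy group, an amine or a carboxylic acid would give a number close to those of compound 2 and compound 3 or one closer to that of compound 1. They also leave open whether a plain phenyl group would group with the two substituted phenyl compounds or with compound 1, which would help show whether the substituent or the change of ring accounts for the difference from pyridin-2-yl.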